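The compounds below may be only part of what the source reports. "The series", "measured", "known", "first", "only" and "open" are said of these compounds alone.

Compound 1, `COc1ccc(-c2cnc3nc(N)nc(NC(C)C)c3n2)cc1OC`, is the starting point. Within the data shown here, in a functional assay on cells (T-cell, Homo sapiens) for inhibition (on this read-out lower numbers stand for stronger inhibition and higher numbers for weaker inhibition), compound 1 gives 600 nM, the lowest of the three numbers measured so far. Compound 2, `COc1ccc(-c2cnc3nc(N)nc(N4CCN(Cc5ccccc5F)CC4)c3n2)cc1OC`, gives 700 nM, and since that lies within the scatter of the value of compound 1, the two cannot be told apart. Compound 3, `COc1ccc(-c2cnc3nc(N)nc(N4CCN(Cc5c(Cl)cccc5Cl)CC4)c3n2)cc1OC`, gives 7600 nM, a much weaker result. Among the measured compounds shown here, the one step among the measured compounds, an 11-fold higher number from compound 2 to compound 3 (1.04 log units; beyond the scatter), shows how strongly a change at the outer end of the substituent on the shared core can move the read-out.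

Compound 4, `COc1ccc(-c2cnc3nc(N)nc(NCc4cccs4)c3n2)cc1OC`, differs from compound 1 in one place: (thiophen-2-yl)methyl in place of isopropyl on a nitrogen on an aromatic ring. For the measured compounds named here, no measured step exchanges a small chain for an arylmethyl on this nitrogen, so the measured step offers only a loose guide. The values of compound 1 and compound 2 show that a considerably larger group at this position can be carried without loss. Compound 4 is therefore expected to show a 1.3-fold higher number from compound 1 to compound 4 (0.12 log units; within the scatter), a shift within the scatter, with an estimated value of 800 nM and a range from 200 nM to 4000 nM.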

Compound 4, half-maximal inhibitory concentration: 4100 nM
Compound 4: the middle estimate sits 5.1-fold (0.71 log units) below what was measured; the whole stated range lies below it.
By their numbers in this assay, from the lowest: compounds 1 and 2 (each within the scatter of the next); then compounds 4 and 3 (each within the scatter of the next).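

In this assay the exchange of isopropyl for (thiophen-2-yl)methyl on a nitrogen on an aromatic ring gives a 6.8-fold higher number from compound 1 to compound 4 (0.83 log units; beyond the scatter) and so shows that this position responds to what sits directly on that nitrogen. The matching values of compound 1 and compound 2 therefore cannot be read as a sign that any bigger group is carried here without loss, since this group, with its six heavy atoms against three, gives a clearly weaker result. Nothing measured here explains why this exchange has such an effect.

The compounds shown leave open whether the weaker result belongs to the thiophene ring itself or to any aromatic ring held on a single chain carbon. A benzyl or a (furan-2-yl)methyl group on the same nitrogen, or a longer open chain such as n-butyl, would help to separate these possibilities.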